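Aryl sulfonamide series: difluorophenyl to dimethylphenyl

The compounds below may be only part of what the source reports. "The series", "measured", "known", "first", "only" and "open" are said of these compounds alone.

Of the compounds shown here, three have been measured in a functional assay on DLD-1 cells (Homo sapiens) for antiproliferative activity, read by CellTiter-Glo, with a stated time of 72 h; a higher number here means a weaker inhibitor, a lower number a stronger inhibitor. Compound 1 `CC1CCN(C2CCN(S(=O)(=O)c3cn(C)cn3)CC2)CC1` gives only a limit, > 5000 nM. Compound 2 `Cc1cc(C)c(S(=O)(=O)N2CCC(C3OCC(C)CO3)CC2)c(C)c1` likewise gives only a limit, > 5000 nM. Going by the values given here, compound 3 `CC1CCN(C2CCN(S(=O)(=O)c3ccc(F)cc3F)CC2)CC1` gives 102 nM, the sole number in the set; the two other values sit at the limit of > 5000 nM in this assay, at which 2 of the 3 values shown sit. Among the compounds with values here, the one measured step, an at least 49-fold lower number from compound 1 to compound 3 (1.69 log units; beyond the scatter), is large.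

Compound 4 `Cc1ccc(S(=O)(=O)N2CCC(N3CCC(C)CC3)CC2)cc1C` is the next member. 3,4-dimethylphenyl in place of 2,4-difluorophenyl on a sulfonyl sulfur The measured step from compound 1 to compound 3 swaps a heteroaromatic ring for a carbocyclic one; the present change keeps the six-membered carbon ring and alters only its substituents, so that step does not directly carry over. Within the data shown here, compound 2 carries a methylated phenyl on the sulfonyl sulfur and gives only a limit, but its core differs from that of compound 3, so no step between them is defined.

Compound 4 is therefore expected to remain in the measurable range, with a modest loss estimated: a 2.9-fold higher number from compound 3 to compound 4 (0.47 log units; beyond the scatter). The estimate for compound 4 is 300 nM, within 70 nM to 1500 nM.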

Compound 4, half-maximal inhibitory concentration: 24 nM
The estimate for compound 4 lay 13-fold (1.10 log units) above the measured number; measured number outside the range, below it.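

At the group on the sulfonyl sulfur, this assay records a 4.3-fold lower number from compound 3 to compound 4 (0.63 log units; beyond the scatter), so fluorine on the phenyl ring is not required for activity in this pair, and 3,4-dimethylphenyl gives the lower number. The exchange keeps the heavy-atom count and the six-membered aromatic ring of carbon only. The two groups differ in the substituents on that ring, and there is no change of ring type as in the earlier step. Against the 1-methyl-1H-imidazol-4-yl group the gap reaches an at least 200-fold lower number from compound 1 to compound 4 (2.31 log units; beyond the scatter), a step that rests on a limit of the assay and not on a number: the limit of > 5000 nM in this assay, at which 2 of the 4 values shown sit.

As far as these compounds go, it remains open whether one methyl group alone accounts for the shift, or whether a chloro or methoxy group on the phenyl ring would serve equally. The compounds shown also do not tell whether the shift carries over to another core.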